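Amine substituent change on the shared core

A few compounds are considered here, and "the series" means these few. Any claim that something is new, unique, unknown or untested is made for them only; others in the source may bear on it.

Compound 3 `C[C@@H](NC1CCN(CCCc2c[nH]c3ccc(-n4cnnc4)cc23)CC1)c1ccccc1` has the lowest number of the three compounds measured in an assay on CHO cells for displacement of a labelled ligand from 5-hydroxytryptamine receptor 1D (Homo sapiens); a higher number here means a weaker inhibitor, a lower number a stronger inhibitor; compound 3 gives 0.4 nM. Compound 1 `O=S(=O)(NCC1CCN(CCCc2c[nH]c3ccc(-n4cnnc4)cc23)CC1)c1ccccc1` gives 6.2 nM and compound 2 `COC[C@H](NC1CCN(CCCc2c[nH]c3ccc(Cn4cncn4)cc23)CC1)c1ccc(F)cc1` gives 5 nM, both beyond the scatter above compound 3. Among the measured compounds shown here, the only single-point step among the measured compounds is a 16-fold lower number from compound 1 to compound 3 (1.19 log units; beyond the scatter), which shows that the group on the amine attached to the saturated ring carbon sets potency strongly.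

Compound 4 `c1cncc(CNC2CCN(CCCc3c[nH]c4ccc(-n5cnnc5)cc34)CC2)c1` is the next member, differing from compound 3 by (pyridin-3-yl)methyl in place of 1-phenylethyl on an amine nitrogen. For the measured compounds named here, no measured step covers this pair: compound 2 also carries a different amine substituent, but it differs from compound 3 in more than one place, so its value shows only that another amine variant sits well above compound 3. Because the step of a 16-fold lower number from compound 1 to compound 3 (1.19 log units; beyond the scatter) was large, and because compound 3 sits at 0.4 nM as the lowest number seen, a move upward from compound 3 is the more likely outcome, with its size uncertain. The expected step is a 7.5-fold higher number from compound 3 to compound 4 (0.88 log units; beyond the scatter). Compound 4 is estimated at 3 nM, with a range from 0.8 nM to 12 nM.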

Compound 4, half-maximal inhibitory concentration: 35 nM
For compound 4 the middle estimate is 12-fold (1.07 log units) below the measured one, outside the stated range (above it).
By their numbers in this assay, from the lowest: compound 3; then compounds 2 and 1 (each within the scatter of the next); then compound 4.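

With the secondary amine on the saturated ring carbon kept, an 88-fold higher number from compound 3 to compound 4 (1.94 log units; beyond the scatter) in this assay shows that this amine linkage does not by itself give a low number: the group on the nitrogen decides much of the result, and (pyridin-3-yl)methyl is a poor replacement for 1-phenylethyl here. The comparison with the sulfonamide side chain also changes direction, with a 5.6-fold higher number from compound 1 to compound 4 (0.75 log units; beyond the scatter), so the gain seen for (1-phenylethyl)amino over ((phenylsulfonyl)amino)methyl does not carry over to ((pyridin-3-yl)methyl)amino. No measurement available here accounts for the rise in the number.

The change to compound 4 removes the defined stereocentre and the methyl branch and also brings a nitrogen into the aromatic ring, so the compounds shown leave open which of these differences carries the step. A benzyl group or a 1-(pyridin-3-yl)ethyl group on the same amine nitrogen would separate them, and the opposite stereoisomer of the 1-phenylethyl group would show how much the stereocentre's configuration matters in this series.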